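Chain substituents on the shared core: toward compound 4

This account rests on a few compounds, and the source may have more. Where it says the series, first, only, none or still open, it means among the compounds named here.

compound 1 `CCn1c(N)c(-c2nc3ccccc3[nH]2)c2nc(C#N)c(C#N)nc21`: > 50000 nM
compound 2 `CN1CCN(CCn2c(N)c(-c3nc4ccccc4[nH]3)c3nc(C#N)c(C#N)nc32)CC1`: > 50000 nM
compound 3 `CCN(CC)CCCCn1c(N)c(-c2nc3ccccc3[nH]2)c2nc(C#N)c(C#N)nc21`: 10100 nM

In a functional assay on HeLa cells (Homo sapiens) for antiproliferative activity, read by MTT assay, with a stated time of 48 h (a higher number here means a weaker inhibitor, a lower number a stronger inhibitor), compound 1 reaches only > 50000 nM, which is a limit of the assay and not a number. Compound 2 likewise ends at a limit, > 50000 nM. Compound 3 alone gives a number, 10100 nM. The step of an at least 4.9-fold lower number from compound 1 to compound 3 (0.69 log units; beyond the scatter) and the step of an at least 4.9-fold lower number from compound 2 to compound 3 (0.69 log units; beyond the scatter) are therefore read only as lower bounds, while the step that the two limits leave unreadable from compound 1 to compound 2 cannot be read at all; the shared reason is the limit of > 50000 nM in this assay, at which 2 of the 3 values shown sit, where compound 1 stands.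

Compound 4 `N#Cc1nc2c(-c3nc4ccccc4[nH]3)c(N)n(CCCNc3ccccc3)c2nc1C#N` differs from compound 1 by anilinomethyl in place of hydrogen on a saturated chain carbon, two bonds along the chain from an aromatic nitrogen. Among the compounds with values here, the one step from compound 1 that is readable, an at least 4.9-fold lower number from compound 1 to compound 3 (0.69 log units; beyond the scatter), came from a basic chain end, and compound 4 carries a neutral one, so a smaller gain is expected: the estimated step is an at least 2.0-fold lower number from compound 1 to compound 4 (0.30 log units; that floor lies within the scatter). Compound 4 is thus expected in this assay near 25000 nM, between 6000 nM and 100000 nM, with a fair chance of again ending at a limit.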

Compound 4, half-maximal inhibitory concentration: 26300 nM
The estimate for compound 4 lay 1.1-fold (0.02 log units) below the measured number; the measured number falls inside the stated range.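

Compound 4 is a second chain end that gives a number in this assay, and its 3-anilinopropyl carries no net charge, so a readable value at this place is not confined to the diethylamino chain end of compound 3. Two numbers can now be compared directly at this place: a 2.6-fold higher number from compound 3 to compound 4 (0.42 log units; beyond the scatter) is a modest step in favour of the diethylamino chain end. Against the other two compounds only floors can be read, an at least 1.9-fold lower number from compound 1 to compound 4 (0.27 log units; that floor lies within the scatter) and an at least 1.9-fold lower number from compound 2 to compound 4 (0.27 log units; that floor lies within the scatter), and the true size of these steps stays unknown because of the limit: the limit of > 50000 nM in this assay, at which 2 of the 4 values shown sit.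

As far as these compounds go, how much of the difference belongs to chain length and how much to the chain end stays open. A morpholine on the 3-carbon chain, or anilino on a longer chain, would separate the two.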